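The source may report more compounds than this note shows. Statements on the series, on what has been measured and on what is new or still open speak of the compounds shown alone.

Compound 1 `COc1ccc(C(=O)N(CCC(=O)NCc2ccccc2)Cc2ccc(C(=O)NO)cc2)cc1` stands as the weaker of the two measured compounds: in a functional assay on G55T2 cells (Homo sapiens) for antiproliferative activity, read by WST assay, with a stated time of 72 h (a lower number here means a stronger inhibitor, a higher number a weaker inhibitor), compound 1 gives 3490 nM, while compound 2 `Cc1ccc(NC(=O)CCN(Cc2ccc(C(=O)NO)cc2)C(=O)c2ccc(N(C)C)cc2)cc1` gives 330 nM. Compound 3 `COc1cc(OC)cc(C(=O)N(CCC(=O)NCc2ccccc2)Cc2ccc(C(=O)NO)cc2)c1` differs from compound 1 in a single place: 3,5-dimethoxyphenyl in place of 4-methoxyphenyl on a carbonyl carbon. Within the data shown here, no measured pair shows this change, so its effect in this assay is unknown from these data; the expected step is small, with no direction beyond the usual scatter. For compound 3 the estimate is 3500 nM, with a range from 1500 nM to 8000 nM. This estimate means an expected step of a 1.0-fold higher number from compound 1 to compound 3 (0.00 log units; within the scatter).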

Compound 3, half-maximal inhibitory concentration: 14700 nM
Beside the measured number, compound 3's estimate is 4.2-fold (0.62 log units) below it; measured number outside the range, above it.
By their numbers in this assay, from the lowest: compound 2; then compound 1; then compound 3.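

On the carbonyl carbon whose other neighbour is the amide-type nitrogen, the choice of aryl group does register in this assay: 3,5-dimethoxyphenyl in place of 4-methoxyphenyl gives a 4.2-fold higher number from compound 1 to compound 3 (0.62 log units; beyond the scatter). Among these compounds, this single pair is the first direct reading at this position, and it shows the change weakening the compound rather than leaving it level. No measured evidence on hand accounts for this step.

Still open, from the compounds shown here alone, is how an unsubstituted phenyl, a 3-methoxyphenyl or a pyridine ring would read on the same carbonyl carbon. One pair cannot show whether the loss follows from the added methoxy group or from its placement.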